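A few compounds are considered here, and "the series" means these few. Any claim that something is new, unique, unknown or untested is made for them only; others in the source may bear on it.

Three compounds have been measured in an ADME assay on the whole organism with Oryza sativa as the target, tested at 1 uM; a lower number here means a stronger effect, a higher number a weaker effect of the compound at the concentration tested:

Compound 1, `CCOC(=O)c1cccc(NC(=O)N[C@@H](C)c2ccccc2)c1`, gives 99%.
Compound 2, `CCOC(=O)c1ccc(NC(=O)N[C@H](C)c2ccccc2)cc1`, gives 100%.
Compound 3, `CC(=O)c1cccc(NC(=O)N[C@@H](C)c2ccccc2)c1`, gives 95%.

Compound 3 differs from compound 1 by methyl in place of ethoxy on a carbonyl carbon, and in this assay this gives a number 4 percentage points lower from compound 1 to compound 3 (within the scatter). Compound 2 has the same atoms as compound 1 joined differently; how the two cores differ is not broken down here, and their values in this assay lie within the scatter of each other.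

Compound 4, `CC(=O)c1ccc(NC(=O)N[C@H](C)c2ccccc2)cc1`, has not yet been measured. It differs from compound 2 by methyl in place of ethoxy on a carbonyl carbon, the same change as that from compound 1 to compound 3, at a place described in the same words. Since that change produced a number 4 percentage points lower from compound 1 to compound 3 (within the scatter), compound 4 is expected to show a step of about a number 3 percentage points lower from compound 2 to compound 4 (within the scatter) in this assay, with the understanding that this rests on a single pair. On that basis compound 4 is estimated at 97% in this assay, between 89% and 100%.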

Compound 4, a percentage reported as activity, at one concentration (the size of the read-out at that concentration, not a potency): 93%
Compound 4: middle estimate off by 4 percentage points, on the high side; low and high end bracket the measured number.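

Measured on the second core, methyl in place of ethoxy on a carbonyl carbon gives a number 7 percentage points lower from compound 2 to compound 4 (within the scatter) in this assay. Set beside the earlier step, the change reads alike on the two cores: the same change on two cores in this assay, a number 4 percentage points lower (within the scatter) from compound 1 to compound 3 and a number 7 percentage points lower (within the scatter) from compound 2 to compound 4, 3 percentage points apart, within the scatter of two such steps

This shows that the ethoxycarbonyl to acetyl change can be carried from one core to the other here without the two steps parting beyond the scatter, but each step also lies within the scatter, so it does not show that the change has a real effect on either core, and the agreement rests on just these two pairs.

The compounds shown carry only ethoxy or methyl on the carbonyl carbon, which leaves open what an amine, a hydroxyl giving a carboxylic acid, or a longer chain such as butoxy would do at that place. Going by these compounds, it also remains open whether any group there can move the read-out beyond the scatter.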